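The compounds below may be only part of what the source reports. "The series", "measured", "known", "first", "only" and "open" are said of these compounds alone.

Compound 1 `O=C(O)/C=C/c1ccc(NC(=O)C2(NC(=O)c3ccc4c(c3)nc(-c3ccco3)n4C3CCCCC3)CCC2)cc1` serves as the reference point in an ADME assay on Huh-7 cells (Homo sapiens) for cytotoxicity; on this read-out higher numbers stand for lower toxicity in this test and lower numbers for higher toxicity in this test. In this assay compound 1 gives > 10 uM, which is a limit of the assay and not a number. Compound 2 `O=C(O)/C=C/c1ccc(NC(=O)C2(NC(=O)c3ccc4c(c3)nc(-c3ccsc3)n4C3CCCCC3)CCC2)cc1` sits at the same limit, as in this assay compound 2 gives > 10 uM. Compound 3 `O=C(O)/C=C/c1ccc(NC(=O)C2(NC(=O)c3ccc4c(c3)nc(-c3ccccn3)n4C3CCCCC3)CCC2)cc1` does likewise, since in this assay compound 3 gives > 10 uM. The steps a step that the two limits leave unreadable from compound 1 to compound 2, a step that the two limits leave unreadable from compound 1 to compound 3 and a step that the two limits leave unreadable from compound 2 to compound 3 are therefore of unknown size, because the limit of > 10 uM in this assay, at which 3 of the 3 values shown sit, leaves no number to compare. Compound 4 `Cn1cccc1-c1nc2cc(C(=O)NC3(C(=O)Nc4ccc(/C=C/C(=O)O)cc4)CCC3)ccc2n1C1CCCCC1` differs from compound 1 by 1-methyl-1H-pyrrol-2-yl in place of furan-2-yl on an aromatic carbon. The three measured steps bear on this change as other swaps at the same aromatic carbon, yet none shows a readable size, so no step beyond the scatter is expected, and a step that the limit leaves unreadable from compound 1 to compound 4 is estimated to be flat. For compound 4 in this assay the expected value is 20 uM, in the range 10 uM to 60 uM, most likely again reported only as a limit.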

Compound 4, half-maximal toxic concentration: > 10 uM
Compound 4 was reported as a limit; the forecaster's own chance of this, stated with the estimate: 85%; the middle value lies beyond the limit too.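

Compound 4 is again a limit, so the steps to it from compound 1, compound 2 and compound 3 cannot be read: the limit of > 10 uM in this assay, at which 4 of the 4 values shown sit. In this assay the compounds shown leave open whether any of these four aromatic groups changes the read-out.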